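Triazole carboxamide series: alkyl substituent on the triazole ring

The compounds below may be only part of what the source reports. "The series", "measured", "known", "first", "only" and "open" are said of these compounds alone.

Measured compounds:
- compound 1 `C[C@H](NC(=O)c1cn(Cc2ccc(C(F)(F)F)cc2)nn1)c1ccc(C(=O)O)cc1`: in a functional assay on CHO cells for antagonist activity at prostaglandin E2 receptor EP4 subtype (Homo sapiens), read by calcium flux, with a stated time of 15 min (on this read-out higher numbers stand for weaker inhibition and lower numbers for stronger inhibition), compound 1 gives > 10000 nM, a limit of the assay.
- compound 2 `CCCc1c(C(=O)N[C@@H](C)c2ccc(C(=O)O)cc2)nnn1Cc1ccc(C(F)(F)F)cc1`: in this assay compound 2 gives > 10000 nM, a limit of the assay.
- compound 3 `CCc1nnn(Cc2ccc(C(F)(F)F)cc2)c1C(=O)N[C@@H](C)c1ccc(C(=O)O)cc1`: in this assay compound 3 gives > 10000 nM, a limit of the assay.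

The shared core carries the trifluoromethylbenzyl group on the ring nitrogen and the carboxamide to the chiral benzylic amine bearing the carboxylic acid. All three measured values sit at the same limit (the limit of > 10000 nM in this assay, at which 3 of the 3 values shown sit), so compound 3 stands only at a limit, with no number to order it against the others. Among the measured compounds shown here, the one measured step, a step that the two limits leave unreadable from compound 1 to compound 2, is left unreadable by the two limits.

Compound 4 `C[C@H](NC(=O)c1c(C2CCCC2)nnn1Cc1ccc(C(F)(F)F)cc1)c1ccc(C(=O)O)cc1` differs from compound 3 by cyclopentyl in place of ethyl on an aromatic carbon. For the measured compounds named here, no measured step bears on this change: the only step available, from hydrogen to propyl, cannot be sized. With the three values at the limit, nothing in this assay points to a step beyond the scatter, and the expected step that the limit leaves unreadable from compound 3 to compound 4 is set at none. Compound 4 is therefore estimated at 15000 nM, most likely again a limit, with a range of 3000 nM to 60000 nM.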

Compound 4, half-maximal inhibitory concentration: 65.1 nM
Estimate against measurement, compound 4: 230-fold (2.36 log units) above, outside the stated range (below it).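

In this assay, among the compounds shown here, cyclopentyl in place of ethyl on the aromatic carbon gives an at least 150-fold lower number from compound 3 to compound 4 (2.18 log units; beyond the scatter), the first step that can be read. For the compounds shown here, compound 1 with hydrogen, compound 3 with ethyl and compound 2 with propyl all stand at a limit, while compound 4 with cyclopentyl is the only one with a number, so the group on this carbon can move the read-out far off the limit. The step is a bound and not an exact size because compound 3 stands at a limit: the limit of > 10000 nM in this assay, at which 3 of the 4 values shown sit.

From the compounds shown here alone, whether the ring or the carbon count of cyclopentyl carries the step stays open, and a pentyl chain on this carbon would separate the two. Going by these compounds, how cyclohexyl, phenyl or an amine would read at this carbon also stays open.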